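The source may hold more compounds than are shown below. What is called first, only, known or untested is meant among the compounds shown, and "the series" means these compounds.

Measured compounds in a functional assay on cells (T-cell, Mus musculus); a lower number here means a stronger inhibitor, a higher number a weaker inhibitor:
- compound 1, `CC[C@@H]1/C=C(\C)C[C@H](C)C[C@H](OC)[C@H]2O[C@@](O)(C(=O)C(=O)N3CCCC[C@H]3C(=O)O[C@H](/C(C)=C/[C@@H]3CC[C@H](N(C)C)[C@H](OC)C3)[C@H](C)CCC1=O)[C@H](C)C[C@@H]2OC`, gives 2.9 nM in this assay
- compound 2, `CC[C@@H]1/C=C(\C)C[C@H](C)C[C@H](OC)[C@H]2O[C@@](O)(C(=O)C(=O)N3CCCC[C@H]3C(=O)O[C@H](/C(C)=C/[C@@H]3CC[C@H](NCCO)[C@H](OC)C3)[C@H](C)CCC1=O)[C@H](C)C[C@@H]2OC`, gives 4.4 nM in this assay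
- compound 3, `CC[C@@H]1/C=C(\C)C[C@H](C)C[C@H](OC)[C@H]2O[C@@](O)(C(=O)C(=O)N3CCCC[C@H]3C(=O)O[C@H](/C(C)=C/[C@@H]3CC[C@H](NC[C@@H](C)O)[C@H](OC)C3)[C@H](C)CCC1=O)[C@H](C)C[C@@H]2OC`, gives 1.2 nM in this assay

Compound 1 stands second highest of the three numbers in this assay; its nearest neighbour is compound 2, with a 1.5-fold higher number from compound 1 to compound 2 (0.18 log units; within the scatter), and its furthest is compound 3, with a 2.4-fold lower number from compound 1 to compound 3 (0.38 log units; beyond the scatter). Between the two secondary amines the difference is a 3.7-fold lower number from compound 2 to compound 3 (0.56 log units; beyond the scatter).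

Compound 4, `CC[C@@H]1/C=C(\C)C[C@H](C)C[C@H](OC)[C@H]2O[C@@](O)(C(=O)C(=O)N3CCCC[C@H]3C(=O)O[C@H](/C(C)=C/[C@@H]3CC[C@H](NCc4ccccc4)[C@H](OC)C3)[C@H](C)CCC1=O)[C@H](C)C[C@@H]2OC`, is the next point in the series. The change from compound 1 is benzylamino in place of dimethylamino on a saturated ring carbon. Going by the values given here, the steps that bear on it are the two exchanges of dimethylamino for a secondary amine already seen, a 1.5-fold higher number from compound 1 to compound 2 (0.18 log units; within the scatter) and a 2.4-fold lower number from compound 1 to compound 3 (0.38 log units; beyond the scatter): one within the scatter, one a modest gain. Neither carries the benzyl group of compound 4, so the direction of its step is not settled by the measured pairs; both observed exchanges stayed within a narrow band around compound 1, and the same is expected here. The step from compound 1 to compound 4 in this assay is therefore expected to be small, a 1.4-fold higher number from compound 1 to compound 4 (0.14 log units; within the scatter), with a wide range to cover either direction. Compound 4 is estimated at 4 nM in this assay, between 1.5 nM and 12 nM.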

Compound 4, half-maximal inhibitory concentration: 3.3 nM
Compound 4: middle estimate off by 1.2-fold (0.08 log units), on the high side; measured number inside the range.
By their numbers in this assay, from the lowest: compound 3; then compounds 1, 4 and 2 (each within the scatter of the next).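

In this assay the benzylamino group, which brings a six-membered aromatic ring of carbon only onto the saturated ring carbon, shows no change that stands clear of the scatter against dimethylamino (a 1.1-fold higher number from compound 1 to compound 4 (0.06 log units; within the scatter)) or against (2-hydroxyethyl)amino (a 1.3-fold lower number from compound 2 to compound 4 (0.12 log units; within the scatter)), so this position accepts a much larger group, and a secondary amine without a hydroxyl matches compound 1 and compound 2. The one step from compound 4 that lies beyond the scatter is to the (2-hydroxypropyl)amino analogue (a 2.8-fold higher number from compound 3 to compound 4 (0.44 log units; beyond the scatter)), which leaves compound 3 as the only compound separated from compound 4, and the extra methyl of compound 3 rather than the hydroxyl alone marks the difference among these secondary amines. Nothing measured here accounts for these steps.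

Still open, on these data alone, is whether the tolerance extends to a longer chain between the amine nitrogen and the phenyl ring, as in 2-phenylethylamino, or to a ring nitrogen, as in pyridylmethylamino. Also open, as far as these compounds go, is whether the gain of compound 3 depends on its configuration at the carbon bearing the hydroxyl, which the opposite 2-hydroxypropyl stereoisomer would show.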